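Dropping an Aromatic Methyl from a Chloroacetamide Cytotoxin

The source may report more compounds than this note shows. Statements on the series, on what has been measured and on what is new or still open speak of the compounds shown alone.

Compound 1 `CN(C)CCN1CCN(CC(=O)Nc2ccc(-c3nc4cc(Cl)ccc4o3)cc2)CC1`: 7920 nM in a functional assay on MCF7 cells (Homo sapiens) for cytotoxicity, read by MTT assay, with a stated time of 24 h; a higher number here means a weaker inhibitor, a lower number a stronger inhibitor
Compound 2 `Cc1ccc2oc(-c3ccc(NC(=O)CN4CCN(CCN(C)C)CC4)c(C)c3)nc2c1`: 90300 nM
Compound 3 `Cc1cc(-c2nc3cc(F)ccc3o2)ccc1NC(=O)CCl`: > 100000 nM, which is a limit of the assay and not a number.

The read-out of this assay is the inhibitory concentration against the cells, so a small number marks a strong compound. On these data alone, compound 3 stands at the limit of > 100000 nM in this assay, at which 1 of the 3 values shown sits, meaning that no inhibition strong enough to measure was seen within the tested range, and its true value is unknown. Of the two compounds with numbers, compound 1 gives 7920 nM and compound 2 gives 90300 nM, so compound 1 sits well below compound 2; the two differ in several places, and nothing more can be drawn from them.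

Compound 4 `O=C(CCl)Nc1ccc(-c2nc3cc(F)ccc3o2)cc1` differs from compound 3 by hydrogen in place of methyl on an aromatic carbon, in words hydrogen in place of methyl on an aromatic carbon. Within the data shown here, no measured pair shows this single change, so the direction of its effect is open. Since compound 3 is known only as a limit, compound 4 is expected to be at best a modest improvement, and the step from compound 3 to compound 4 is estimated as an at least 1.6-fold lower number from compound 3 to compound 4 (0.22 log units; that floor lies within the scatter). Compound 4 is therefore expected near 60000 nM, with a plausible range from 15000 nM to 200000 nM.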

Compound 4, half-maximal inhibitory concentration: 3260 nM
For compound 4 the middle estimate is 18-fold (1.26 log units) above the measured one, outside the stated range (below it).
By their numbers in this assay, from the lowest: compound 4; then compound 1; then compound 2. At a limit, above all of these: compound 3.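

Among the compounds shown, this is the first pair that differs in one place, so the effect of this position can now be read directly. In this assay, hydrogen in place of methyl on the aromatic carbon ortho to a ((chloromethyl)carbonyl)amino group gives an at least 30-fold lower number from compound 3 to compound 4 (1.48 log units; beyond the scatter), a large step well beyond the usual scatter. This single methyl therefore separates a compound with a measurable value from one that reaches the end of the assay's range, and the true size of the step stays unknown because the value of compound 3 is a limit of the assay and not a number: the limit of > 100000 nM in this assay, at which 1 of the 4 values shown sits.

The compounds shown leave open whether it is the methyl itself that matters at this position or whether any group there would have the same effect, a question that a methoxy group or an ethyl group would help to answer. They also leave open whether the same change would carry over to the amine side chain of compound 1 and compound 2, since those two differ from each other in several places.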